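The compounds below may be only part of what the source reports. "The series", "measured", "known", "first", "only" and "open" are said of these compounds alone.

Compound 1 `CN(C(=O)C(C)(C)C)c1ccc2[nH]c(-c3n[nH]c4ccccc34)cc2n1` was tested in a functional assay on A549 cells (Homo sapiens) for antiproliferative activity, read by MTT assay, with a stated time of 72 h (a lower number here means a stronger inhibitor, a higher number a weaker inhibitor), where compound 1 gives 24400 nM. Among the three measured compounds it holds the second highest number; compound 3 `CN(C(=O)c1ccccc1)c1ccc2[nH]c(-c3n[nH]c4cc(C#N)ccc34)cc2n1` gives 32800 nM, a result within the scatter of compound 1, while compound 2 `CN(C(=O)c1ccccc1)c1ccc2[nH]c(-c3n[nH]c4cc(Cl)ccc34)cc2n1` gives 9590 nM and so stands clearly lower. Among the measured compounds shown here, the one step between compounds that differ in a single place is a 3.4-fold higher number from compound 2 to compound 3 (0.53 log units; beyond the scatter), which concerns a group on an aromatic carbon of the shared core and not the nitrogen changed here.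

Compound 4 `CN(c1ccc2[nH]c(-c3n[nH]c4ccccc34)cc2n1)S(=O)(=O)c1ccccc1` differs from compound 1 in one place: phenylsulfonyl in place of (tert-butyl)carbonyl on a nitrogen on an aromatic ring. For the measured compounds named here, no measured step touches this nitrogen. Compounds 2 and 3 carry a different carbonyl group on it, but they also differ elsewhere, so their values give no clean guide. With nothing bearing on the change, no step beyond the scatter is expected, and the estimate for compound 4 is 22000 nM with a range of 6000 nM to 80000 nM. This estimate means a step of a 1.1-fold lower number from compound 1 to compound 4 (0.04 log units; within the scatter) is expected.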

Compound 4, half-maximal inhibitory concentration: 14000 nM
The estimate for compound 4 lay 1.6-fold (0.20 log units) above the measured number; measured number inside the range.
By their numbers in this assay, from the lowest: compounds 2, 4, 1 and 3 (each within the scatter of the next, the first and the last beyond it).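

Among the compounds shown here, this is the first measured change at the nitrogen on the aromatic ring: in this assay, phenylsulfonyl in place of (tert-butyl)carbonyl gives a 1.7-fold lower number from compound 1 to compound 4 (0.24 log units; within the scatter). The entering group has more heavy atoms and brings an aromatic ring, yet the result cannot be told apart from that of compound 1. A carbonyl on this nitrogen is therefore not required for a number of this size, and no measurement at hand explains why the two groups read alike.

Still open, from the compounds shown here alone, is how this nitrogen responds to very different groups, such as a carboxylic acid, an amine on a longer chain, or a plain hydrogen. Also open, going by these compounds, is whether a chloro or cyano group on the shared core would give the same reading alongside phenylsulfonyl.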